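Opening the Sulfur Ring of Compound 2

The compounds below may be only part of what the source reports. "The series", "measured", "known", "first", "only" and "open" are said of these compounds alone.

Of the compounds shown here, three have so far been tested in a functional assay on HO8910 cells (Homo sapiens) for inhibition, read by MTT assay, with a stated time of 24 h, tested at 1 ug/mL; on this read-out higher numbers stand for more inhibition of growth at the one concentration tested and lower numbers for less inhibition of growth. Compound 2 `O=C(CCCCC1CCSS1)Nc1ccccn1` is reported only as "not active" (no number reported), so no single number places it. Compound 1 `O=C(CCCCC(S)CCS)NO` is also reported as "not active" (no number reported). Among the measured compounds shown here, compound 3 `O=C(CCCCC1CCSS1)Nc1ccc(Cl)cn1` gives 2.1%, the only number available. Compound 2 therefore sits in a set where little or no growth inhibition has been seen at the one concentration tested.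

Compound 4 `O=C(CCCCC(S)CCS)Nc1ccccn1` has not yet been measured. For the measured compounds named here, the single structural change is a group of 5 heavy atoms (3 carbon, 2 sulfur; no ring) in place of a group of 5 heavy atoms (3 carbon, 2 sulfur; one five-membered non-aromatic ring with 2 hetero atoms), on a saturated chain carbon, four bonds along the chain from a carbonyl carbon. The five-membered non-aromatic ring leaves, and 1,3-disulfanylpropyl, which has no ring, enters in its place.

No step beyond the usual scatter is expected in this assay, and neither direction is favoured. Compound 1 already carries 1,3-disulfanylpropyl and is reported as "not active" (no number reported), so the open group gives no sign of a gain. Compound 4 is estimated at 4%, with an expected range from 0% to 15%.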

Compound 4, percent growth inhibition at one concentration: "not active" (no number reported)
The entry for compound 4 holds no number, so the estimate cannot be set against anything.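

Compound 2 and compound 4 both stand without a number in this assay, so no step can be read between them. Nothing measured here offers an explanation for this result. From the compounds shown here alone, whether 1,3-disulfanylpropyl and the five-membered ring differ at all in growth inhibition remains open.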